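Moving the ethyl group around the phenyl ring

The compounds below may be only part of what the source reports. "The series", "measured", "known", "first", "only" and "open" are said of these compounds alone.

Measured so far:
- compound 1, `Cc1ccccc1-n1cc(COc2cccc(NC(=O)Nc3ccc(Cl)c(C(F)(F)F)c3)c2)nn1`: 3440 nM
- compound 2, `CCc1cccc(-n2cc(COc3cccc(NC(=O)Nc4ccc(Cl)c(C(F)(F)F)c4)c3)nn2)c1`: 37900 nM

Among the compounds with values here, in a functional assay on HepG2 cells (Homo sapiens) for inhibition, read by MTT assay, with a stated time of 72 h (a lower number here means a stronger inhibitor, a higher number a weaker inhibitor), compound 2 gives 37900 nM, the highest of the two numbers available, with compound 1 as its only neighbour at 3440 nM. Within the data shown here, the one measured step, an 11-fold higher number from compound 1 to compound 2 (1.04 log units; beyond the scatter), changes both the group on the aromatic nitrogen and where that group sits, so it cannot be separated into the effect of the group and the effect of its position.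

Compound 3, `CCc1ccc(-n2cc(COc3cccc(NC(=O)Nc4ccc(Cl)c(C(F)(F)F)c4)c3)nn2)cc1`, keeps the same atoms as compound 2 but joins them differently: 4-ethylphenyl in place of 3-ethylphenyl on an aromatic nitrogen. Among the measured compounds shown here, no measured pair shows what moving the ethyl group within the phenyl ring does on its own. The step from compound 1 to compound 2 shows that a change in this part of the molecule can matter a great deal, but it gives no direction for this particular move. For compound 3 the expected step in this assay is therefore a 1.9-fold lower number from compound 2 to compound 3 (0.28 log units; within the scatter), with a wide range around it. The estimate for compound 3 in this assay is 20000 nM, spanning 5000 nM to 80000 nM.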

Compound 3, half-maximal inhibitory concentration: 1950 nM
Beside the measured number, compound 3's estimate is 10-fold (1.01 log units) above it; measured number below the stated range.
By their numbers in this assay, from the lowest: compounds 3 and 1 (each within the scatter of the next); then compound 2.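

With the atoms held the same, the position of the ethyl group on the phenyl ring is enough on its own to shift the result in this assay: the change to 4-ethylphenyl gives a 19-fold lower number from compound 2 to compound 3 (1.29 log units; beyond the scatter) and so separates position from group, which the earlier step could not do. The change from 2-methylphenyl to 4-ethylphenyl gives a 1.8-fold lower number from compound 1 to compound 3 (0.25 log units; within the scatter) and therefore does not tell these two groups apart. Of the three groups on the aromatic nitrogen, 3-ethylphenyl alone stands clearly apart from the others, so a substituent on this phenyl ring is not in itself a problem, and the outcome depends on which group is present and where it sits.

No available evidence explains why moving the ethyl group has so large an effect. From the compounds shown here alone, it also remains open whether a longer chain such as propyl, or an amine or a carboxylic acid in place of the ethyl group, would keep the number of compound 3 or change it, and whether the same dependence on position would hold for those groups.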